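Opening a tertiary amide on the ester chain

The source may hold more compounds than are shown below. What is called first, only, known or untested is meant among the compounds shown, and "the series" means these compounds.

Measured compounds:
- compound 1, `CCOc1cc(NC(=O)C2(NC(=O)c3ccc4c(C5CCCC5)c(-c5ncc(Cl)cn5)n(C)c4c3)CCC2)ccc1/C=C/C(=O)OCCOCCOC`: < 30000 ug/mL
- compound 2, `CCOc1cc(NC(=O)C2(NC(=O)c3ccc4c(C5CCCC5)c(-c5ncc(Cl)cn5)n(C)c4c3)CCC2)ccc1/C=C/C(=O)OCC(N)=O`: < 200000 ug/mL

In an ADME assay for solubility (on this read-out higher numbers stand for higher solubility and lower numbers for lower solubility), compound 1 gives a value that is a limit of the assay, (the limit of < 30000 ug/mL in this assay, at which 1 of the 2 values shown sits). Compound 2 likewise gives only a limit in this assay, (the limit of < 200000 ug/mL in this assay, at which 1 of the 2 values shown sits). Between the two stands a step that the two limits leave unreadable from compound 1 to compound 2, so the size of that step cannot be read. Compound 2 therefore stands at a limit and nowhere firmer on the numbers shown.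

Compound 3, `CCCN(C)C(=O)COC(=O)/C=C/c1ccc(NC(=O)C2(NC(=O)c3ccc4c(C5CCCC5)c(-c5ncc(Cl)cn5)n(C)c4c3)CCC2)cc1OCC`, differs from compound 2 by methyl(propyl)amino in place of amino on a carbonyl carbon. For the measured compounds named here, no measured step bears directly on this change, and the one measured step is itself unreadable. The step that the limit leaves unreadable from compound 2 to compound 3 is therefore estimated with low confidence and no firm direction beyond the scatter. Compound 3 is expected to give 30000 ug/mL in this assay, with a range from 3000 ug/mL to 200000 ug/mL.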

Compound 3, solubility: < 200000 ug/mL
Compound 3: no number, only a limit (the forecaster's own chance of this, stated with the estimate: 50%); the middle value lies beyond the limit too.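

In this assay, for the compounds shown here, compound 3 also gives only a limit, so no step among compound 1, compound 2 and compound 3 can be read: the limit of < 200000 ug/mL in this assay, at which 2 of the 3 values shown sit. As far as these compounds go, what methyl(propyl)amino in place of amino on a carbonyl carbon does to solubility stays open, as does the actual solubility of all three compounds.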